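A few compounds are considered here, and "the series" means these few. Any claim that something is new, unique, unknown or untested is made for them only; others in the source may bear on it.

Notes on the series around compound 1, `O=C(Nc1ccc2nc(NC(=O)C3CCCCC3)sc2c1)c1ccccc1C(F)(F)F`. Going by the values given here, in a functional assay on WI-38 VA13 cells (Homo sapiens) for cytotoxicity (a higher number here means that more compound is needed for the effect, a lower number that less compound is needed), compound 1 gives 0.024 ug/mL, the only exact number so far. Compound 2, `O=C(Nc1ccc2nc(NC(=O)C3CCCCC3)sc2c1)c1ccc(Br)cc1`, reads > 4 ug/mL, which is a limit of the assay. Compound 3, `O=C(Nc1ccc2nc(NC(=O)C3CCCCC3)sc2c1)c1c(Cl)cccc1Cl`, has 2,6-dichlorophenyl in place of 2-(trifluoromethyl)phenyl on a carbonyl carbon. Among the compounds with values here, the one measured step at this place is large and beyond the scatter: an at least 160-fold higher number from compound 1 to compound 2 (2.22 log units; beyond the scatter). That single step suggests a real rise in this assay, though a smaller one. The expected step is a 6.3-fold higher number from compound 1 to compound 3 (0.80 log units; beyond the scatter). Compound 3 is estimated at 0.15 ug/mL, with an expected range of 0.015 ug/mL to 2 ug/mL.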

Compound 3, half-maximal effective concentration: 0.015 ug/mL
Beside the measured number, compound 3's estimate is 10-fold (1.00 log units) above it; the range from low to high includes it.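

At this place on the carbonyl carbon, 2-(trifluoromethyl)phenyl can be replaced without a change beyond the scatter in this assay: 2,6-dichlorophenyl gives a 1.6-fold lower number from compound 1 to compound 3 (0.20 log units; within the scatter). Set against 4-bromophenyl, the same group gives an at least 260-fold lower number from compound 2 to compound 3 (2.42 log units; beyond the scatter). Compound 2 reads as a limit of the assay and not as a number: the limit of > 4 ug/mL in this assay, at which 1 of the 3 values shown sits.

From the compounds shown here alone, it remains open whether the reading of compound 2 follows from the bromine itself or from where it sits on the ring. Also open, going by these compounds, is how an unsubstituted phenyl or a pyridine would read at this place.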